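The compounds below may be only part of what the source reports. "The series", "measured", "known", "first", "only" and "open" are said of these compounds alone.

Three compounds share the same core and differ in the piece that links it to a cyclic imide. Compound 1, `COc1ccccc1N1CCN(C/C=C/CN2C(=O)CCC2=O)CC1`, has an unsaturated chain with its double bond drawn E; in an assay on isolated protein for binding affinity to 5-hydroxytryptamine receptor 7 (Rattus norvegicus), read by radioligand binding (a higher number here means a weaker inhibitor, a lower number a stronger inhibitor), compound 1 gives 63 nM. Compound 2, `COc1ccccc1N1CCN([C@H]2CC[C@H](N3C(=O)CCC3=O)CC2)CC1`, replaces the chain by a saturated ring; in this assay compound 2 gives 11500 nM. Compound 3, `COc1ccccc1N1CCN(C/C=C/CN2C(=O)c3ccccc3C2=O)CC1`, keeps the E double bond of compound 1 but carries a larger cyclic imide; in this assay compound 3 gives 36 nM, the lowest of the three numbers. Its nearest neighbour is compound 1, whose number lies within the usual scatter, so the two cannot be ranked; the furthest is compound 2, whose number sits far beyond the scatter.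

Compound 4, `COc1ccccc1N1CCN(C/C=C\CN2C(=O)c3ccccc3C2=O)CC1`, is the next step. Relative to compound 3, (the two compounds have the same atoms and bonds and differ only in configuration as drawn: 1 of 1 stereo elements differ; a double bond is drawn E in compound 3 and Z in compound 4). For the measured compounds named here, no measured pair shows a change of this kind, so there is no direct precedent; the only hint that the shape of the linking piece matters comes from compound 2 with 11500 nM against compound 3 with 36 nM. A moderate weakening, somewhat beyond the scatter, is expected for compound 4. In this assay compound 4 is estimated at 150 nM, with a range from 40 nM to 600 nM. That expectation corresponds to a step of a 4.2-fold higher number from compound 3 to compound 4 (0.62 log units; beyond the scatter).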

Compound 4, inhibition constant: 353 nM
The estimate for compound 4 lay 2.4-fold (0.37 log units) below the measured number; measured number inside the range.
By their numbers in this assay, from the lowest: compounds 3 and 1 (each within the scatter of the next); then compound 4; then compound 2.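

In this assay, turning the double bond of the linking chain from E to Z gives a 9.8-fold higher number from compound 3 to compound 4 (0.99 log units; beyond the scatter). For the compounds shown here, this is the first pair here that differs in one place only, so it gives the first direct reading of the linking chain: with the same atoms and the same bonds, the drawn geometry of this one double bond is enough to move the number beyond the usual scatter. The step can be assigned to that geometry alone because nothing else separates the two structures: the fact that compounds 3 and 4 differ only in the configuration as drawn

The result does not show whether the same E to Z switch would move the number by a similar amount with the smaller cyclic imide of compound 1, or why the Z form gives the higher number. From the compounds shown here alone, how a fully saturated open chain or an alkyne in place of the double bond would compare with compound 3 also remains open, and either would help show whether the geometry of the double bond or the double bond itself matters more at this position.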